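From a methylphenyl to a naphthyl group

The source may report more compounds than this note shows. Statements on the series, on what has been measured and on what is new or still open speak of the compounds shown alone.

Compound 1 `c1ccc(-c2cn3ccnc3c(-c3ccc4ncn(C5CCCCC5)c4c3)n2)cc1` gives 27.8%
Compound 2 `Cc1cccc(-c2cn3ccnc3c(-c3ccc4ncn(Cc5ccccc5)c4c3)n2)c1` gives 7.28%

Both were tested in a functional assay on SF-539 cells (Homo sapiens) for inhibition, read by sulforhodamine B assay, with a stated time of 48 h, tested at 10 uM; a lower number here means less inhibition, a higher number more inhibition at the concentration tested (going by the name of the read-out). Compound 2 stands lowest of the two measured compounds, and compound 1 sits higher by a gap beyond the usual scatter. Compound 3 `c1ccc(Cn2cnc3ccc(-c4nc(-c5cccc6ccccc56)cn5ccnc45)cc32)cc1` has not yet been measured. It differs from compound 2 in one place: naphthalen-1-yl in place of 3-methylphenyl on an aromatic carbon. Among the compounds with values here, no measured pair isolates such a change, so the numbers give little guidance. The step is expected to be small, a number 5.7 percentage points higher from compound 2 to compound 3 (within the scatter), not clearly beyond the scatter. Compound 3 is expected to give 13%, within a range from 0% to 35%.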

Compound 3, a percentage reported as inhibition, at one concentration (the size of the read-out at that concentration, not a potency): 4.22%
The estimate for compound 3 lay 8.8 percentage points above the measured number; the range from low to high includes it.
By their numbers in this assay, from the lowest: compounds 3 and 2 (each within the scatter of the next); then compound 1.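

In this assay, putting naphthalen-1-yl in place of 3-methylphenyl on this aromatic carbon gives a number 3.1 percentage points lower from compound 2 to compound 3 (within the scatter). A second six-membered aromatic ring at this position therefore brings no clear difference in the read-out, at least with this shared core. Nothing available explains why the two groups read alike.

Going by these compounds, both groups contain only carbon, so it remains open how a pyridine ring or a phenyl ring carrying an amine would read at this position. On these data alone, whether the same swap would read alike with another group on the core is also open.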